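Swapping ethyl for allyl on a single chain

A few compounds are considered here, and "the series" means these few. Any claim that something is new, unique, unknown or untested is made for them only; others in the source may bear on it.

In a functional assay on MDA-MB-231 cells (Homo sapiens), read by microscopy and transwell migration, with a stated time of 24 h (on this read-out lower numbers stand for stronger inhibition and higher numbers for weaker inhibition), compound 1 `CCn1c(-c2ccc(C)cc2C)cs/c1=N\C(=O)c1ccccc1` gives 1950 nM, while compound 2 `CCn1c(-c2ccccc2)cs/c1=N\C(=O)c1ccccc1` gives 51.5 nM, the lower of the two numbers. Compound 3 `C=CCn1c(-c2ccccc2)cs/c1=N\C(=O)c1ccccc1` differs from compound 2 by vinyl in place of methyl on a saturated chain carbon bound to an aromatic nitrogen, turning ethyl into allyl. Going by the values given here, the only measured step, a 38-fold lower number from compound 1 to compound 2 (1.58 log units; beyond the scatter), was large but changed a different part of the molecule, so it offers little guidance here. No shift beyond the scatter is therefore expected, with any drift slightly upward: the estimated step is a 1.6-fold higher number from compound 2 to compound 3 (0.19 log units; within the scatter). Compound 3 is expected at 80 nM, within an estimated range of 25 nM to 300 nM.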

Compound 3, half-maximal inhibitory concentration: 1200 nM
The estimate for compound 3 lay 15-fold (1.18 log units) below the measured number; the whole stated range lies below it.
By their numbers in this assay, from the lowest: compound 2; then compounds 3 and 1 (each within the scatter of the next).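

Going by these compounds alone, this position is far less tolerant than the earlier compounds could show: in this assay the change from ethyl to allyl gives a 23-fold higher number from compound 2 to compound 3 (1.37 log units; beyond the scatter), so a small edit at the end of one chain produces a large step. Adding a single carbon and a double bond is therefore enough to move the number well beyond the scatter. Nothing available explains this step. From the compounds shown here alone, it remains open whether the added carbon or the double bond matters more, and a propyl chain, the saturated counterpart of allyl, would help separate the two.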